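Removing a chloro from a triazine acrylamide series

The source may report more compounds than this note shows. Statements on the series, on what has been measured and on what is new or still open speak of the compounds shown alone.

Measured so far:
compound 1, `C=CC(=O)Nc1cc(Nc2ncnc(Nc3ccc(C(=O)N4CCCCC4)cc3)n2)ccc1C`: 30600 nM
compound 2, `C=CC(=O)Nc1cccc(Nc2nc(Cl)nc(Nc3ccc(OCCOC)cc3)n2)c1`: "not determined" (no result reported)

The two measured compounds share an acrylamide attached to an aromatic ring and a six-membered aromatic ring with 3 nitrogen as their core. In a functional assay on Raji cells (Homo sapiens) for antiproliferative activity, read by CCK-8 assay, with a stated time of 24 h (a higher number here means a weaker inhibitor, a lower number a stronger inhibitor), compound 1 gives 30600 nM, a weak result. For compound 2 this assay gives "not determined" (no result reported), so there is no number to stand on for compound 2, and its two values with compound 1 cannot be compared.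

Compound 3, `C=CC(=O)Nc1cccc(Nc2ncnc(Nc3ccc(OCCOC)cc3)n2)c1`, is not yet measured. It differs from compound 2 in one place: hydrogen in place of chloro on an aromatic carbon. Hydrogen in place of chloro on an aromatic carbon is a small change in size, and with no measured pair for this kind of step, the expectation is that it moves this assay by no more than the usual scatter in either direction. Within the data shown here, without a number for compound 2, the only anchor is compound 1, whose value is 30600 nM. Compound 3 is therefore expected to be similarly weak, estimated at 25000 nM with a range from 5000 nM to 100000 nM.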

Compound 3, half-maximal inhibitory concentration: 105000 nM
The estimate for compound 3 lay 4.2-fold (0.62 log units) below the measured number; measured number outside the range, above it.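

The swap of chloro for hydrogen between compound 2 and compound 3 cannot be read as a step, as compound 2 has no number in this assay to set against compound 3. From the compounds shown here alone, what that chloro does to activity stays open. No measurement at hand explains the value of compound 3.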